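The compounds below may be only part of what the source reports. "The series", "measured", "known", "first", "only" and "open" are said of these compounds alone.

Working notes on the series

Of the compounds shown here, three of this set have been measured. Compound 1 `Ic1ccccc1C1=NC(c2ccccc2)CO1` gives 3.86 in a physicochemical assay for lipophilicity; a lower number here means a more polar compound, a higher number a more lipophilic compound. Compound 2 `Cc1cccc(C2=NC(c3ccccc3)CO2)c1` gives 4.11 in this assay, and compound 3 `Cc1ccc(C2=NC(c3ccccc3)CO2)cc1` gives 4.11. Compound 1 has the lowest of the three numbers, but its nearest neighbour is compound 2 and its furthest is compound 3, and both of those gaps fall within the scatter of this kind of measurement, so the three values cannot be ordered.

Compound 4 `FC(F)(F)c1ccccc1C1=NC(c2ccccc2)CO1` has not yet been measured. It differs from compound 1 in one place: trifluoromethyl in place of iodo on an aromatic carbon. The change is on an aromatic carbon of a six-membered aromatic ring of carbon only, ortho to a large group, with no change in hydrogen-bond donors, acceptors or charge.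

Within the data shown here, no pair of measured compounds shows this change, so there is no measured step to lean on. The expectation is that the step from compound 1 to compound 4 is small, a number 0.16 log units lower from compound 1 to compound 4 (within the scatter), leaning slightly toward a lower number but not clearly beyond the scatter. On that basis compound 4 is estimated at 3.7, with a range from 3.3 to 4.1.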

Compound 4, partition coefficient: 3.71
Estimate against measurement, compound 4: 0.01 log units below; low and high end bracket the measured number.
By their numbers in this assay, from the lowest: compounds 4, 1, 2 and 3 (each within the scatter of the next, the first and the last beyond it).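

Among these compounds, this position now has its first measured change: in this assay, trifluoromethyl in place of iodo on an aromatic carbon, ortho to a large group, gives a number 0.15 log units lower from compound 1 to compound 4 (within the scatter), so this pair shows no step that can be told from the scatter. The exchange puts 4 heavy atoms where 1 heavy atom stood, with no ring entering or leaving, no hydrogen-bond donors or acceptors on either group and no net charge on either, and for these two groups that difference in heavy atoms comes with no step beyond the scatter. Nothing available explains the size of this step, and the pair alone gives no reason for it.

The compounds shown leave open whether a group with hydrogen-bond donors or a net charge, such as an amine or a carboxylic acid, on this same aromatic carbon would give a step beyond the scatter from compound 1. They also leave open what a longer chain, such as a propyl or butyl group, would give there, and whether trifluoromethyl in place of iodo would give a step of similar size on another aromatic carbon of the ring.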